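Swapping 4-nitrophenyl for 3-methoxyphenyl in compound 3

The source may hold more compounds than are shown below. What is called first, only, known or untested is meant among the compounds shown, and "the series" means these compounds.

Measured in an ADME assay on HEK-293T cells (Homo sapiens) for cytotoxicity, read by CCK-8 assay, with a stated time of 48 h; on this read-out lower numbers stand for stronger inhibition and higher numbers for weaker inhibition:
Compound 1 `Cc1cc(C)cc(NC(=O)NCCNS(=O)(=O)c2ccc(-c3ccccc3Oc3ccc([N+](=O)[O-])c([N+](=O)[O-])c3)s2)c1`: > 50000 nM (a limit)
Compound 2 `COc1cccc(NC(=O)NCCNS(=O)(=O)c2ccc(-c3ccccc3OCc3ccccc3)s2)c1`: > 20000 nM (a limit)
Compound 3 `O=C(NCCNS(=O)(=O)c1ccc(-c2ccccc2Oc2ccc([N+](=O)[O-])c([N+](=O)[O-])c2)s1)Nc1ccc([N+](=O)[O-])cc1`: 16600 nM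

Going by the values given here, compound 3 holds the only true number here, as the other two values are limits. Compound 4 `COc1cccc(NC(=O)NCCNS(=O)(=O)c2ccc(-c3ccccc3Oc3ccc([N+](=O)[O-])c([N+](=O)[O-])c3)s2)c1` differs from it by 3-methoxyphenyl in place of 4-nitrophenyl on an amide-type nitrogen, with 3-methoxyphenyl in place of 4-nitrophenyl on an amide-type nitrogen. Among the compounds with values here, one measured step bears on this change: an at least 3.0-fold lower number from compound 1 to compound 3 (0.47 log units; beyond the scatter), which brought 4-nitrophenyl in place of 3,5-dimethylphenyl at that nitrogen and lies beyond the scatter. Compound 4 gives 4-nitrophenyl up again, so a partial reversal is expected, towards a higher number in this assay. The expected size is a 2.4-fold higher number from compound 3 to compound 4 (0.38 log units; beyond the scatter). The estimate for compound 4 is 40000 nM, with an expected range of 15000 nM to 100000 nM.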

Compound 4, half-maximal inhibitory concentration: 17800 nM
Compound 4: middle estimate off by 2.2-fold (0.35 log units), on the high side; the measured number falls inside the stated range.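

The step of a 1.1-fold higher number from compound 3 to compound 4 (0.03 log units; within the scatter) shows that in this assay 3-methoxyphenyl and 4-nitrophenyl cannot be told apart on this amide-type nitrogen. Both differ from 3,5-dimethylphenyl, so the earlier shift does not belong to 4-nitrophenyl alone: 3-methoxyphenyl also gives an at least 2.8-fold lower number from compound 1 to compound 4 (0.44 log units; beyond the scatter), a step that starts from a limit. The step of an at least 1.1-fold lower number from compound 2 to compound 4 (0.05 log units; that floor lies within the scatter) cannot be read as a real change, since compound 2 has only a limit: the limit of > 20000 nM in this assay, at which 1 of the 4 values shown sits.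

Nothing measured here gives a reason for the match between the two groups. Still open, going by these compounds, is how a cyclohexyl or pyridyl group on that nitrogen would read.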